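A few compounds are considered here, and "the series" means these few. Any claim that something is new, unique, unknown or untested is made for them only; others in the source may bear on it.

Measured in a functional assay on A-431 cells (Homo sapiens) for cytotoxicity, read by MTT assay, with a stated time of 48 h (on this read-out higher numbers stand for weaker inhibition and lower numbers for stronger inhibition), so far:

compound 1, `CCCCCCCCCCCCCCNC(=O)[C@@H](NC(=O)c1ccccc1)[C@@H](C)O`: 118000 nM
compound 2, `CCCCCCCCCCCCCCNC(=O)[C@@H](NC(=O)c1ccco1)[C@@H](C)O`: 190000 nM

Compound 2 and compound 1 are separated only by a 1.6-fold higher number from compound 1 to compound 2 (0.21 log units; within the scatter), so on these two numbers they stand together, and both inhibit growth of these cells only at high concentrations. The change that turned compound 1 into compound 2 sat at the same place as the one examined now: a different aromatic ring on the carbonyl carbon of the amide attached to the core.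

Compound 3, `CCCCCCCCCCCCCCNC(=O)[C@@H](NC(=O)c1cccs1)[C@@H](C)O`, differs from compound 2 by thiophen-2-yl in place of furan-2-yl on a carbonyl carbon. Going by the values given here, the single step that bears on this, the ring swap in this assay from compound 1 to compound 2, stayed within the scatter. A similar exchange of one five-membered ring for another gives no reason to expect more, so compound 3 is expected to show a 1.1-fold lower number from compound 2 to compound 3 (0.05 log units; within the scatter), that is, no step beyond the scatter. Compound 3 is estimated at 170000 nM, with a range from 80000 nM to 350000 nM.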

Compound 3, half-maximal inhibitory concentration: 26500 nM
Estimate against measurement, compound 3: 6.4-fold (0.81 log units) above; the measured number lies below the stated range.
By their numbers in this assay, from the lowest: compound 3; then compounds 1 and 2 (each within the scatter of the next).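

In this assay, putting thiophen-2-yl in place of furan-2-yl gives a 7.2-fold lower number from compound 2 to compound 3 (0.86 log units; beyond the scatter) and putting it in place of phenyl gives a 4.5-fold lower number from compound 1 to compound 3 (0.65 log units; beyond the scatter) as the second step, so compound 3 stands apart from both earlier compounds. The earlier ring swap stayed within the scatter and made this position look indifferent to its ring, but it is not: two five-membered aromatic rings with one hetero atom each, one holding oxygen and the other sulfur, give clearly different numbers here. Nothing available explains why exchanging these two rings has this effect.

Going by these compounds, it remains open whether the gain belongs to thiophen-2-yl alone or would also appear with thiophen-3-yl or a pyridine ring on the same carbonyl carbon. Also open, on these data alone, is whether a chlorine atom on the thiophen-2-yl ring, or a shorter alkyl chain on the shared core, would change the number further.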